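The source may hold more compounds than are shown below. What is called first, only, known or untested is meant among the compounds shown, and "the series" means these compounds.

In a functional assay on HL-60 cells (Homo sapiens) for antiproliferative activity (on this read-out higher numbers stand for weaker inhibition of growth and lower numbers for stronger inhibition of growth), compound 1 (`COCCCCCCCCCCC/C=C1\CC(CO)(COC(=O)C(C)(C)C)OC1=O`) gives 5.22 ug/mL while compound 2 (`CCCCCOCCCCCCC/C=C1\CC(CO)(COC(=O)C(C)(C)C)OC1=O`) gives 2.96 ug/mL and compound 3 (`CC(C)(C)C(=O)OCCCCCCCCCCCCCCC/C=C1\CC(CO)(COC(=O)C(C)(C)C)OC1=O`) gives 7.78 ug/mL on the same core. Compound 3 thus lies within the scatter of compound 1 and stands at a higher number than compound 2, beyond the scatter. Compound 4 (`CC(=O)NCCCCCCCCCCCCCCC/C=C1\CC(CO)(COC(=O)C(C)(C)C)OC1=O`) alters compound 3 in one place (acetamido in place of ((tert-butyl)carbonyl)oxy on a saturated chain carbon, ten or more bonds along the chain from a double-bonded chain carbon) with acetamido in place of ((tert-butyl)carbonyl)oxy on a saturated chain carbon. Within the data shown here, no measured step makes this exchange, but two change the chain: a 1.8-fold lower number from compound 1 to compound 2 (0.25 log units; within the scatter) and a 1.5-fold higher number from compound 1 to compound 3 (0.17 log units; within the scatter) are both small. No step beyond the scatter is therefore expected in this assay and the estimated step is a 1.6-fold lower number from compound 3 to compound 4 (0.19 log units; within the scatter) at most a slight drift. Compound 4 is expected at 5 ug/mL with an estimated range of 2.4 ug/mL to 10.5 ug/mL in this measurement.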

Compound 4, concentration for 50% growth inhibition: > 10 ug/mL
Compound 4: a limit, no number; the forecaster's own chance of this, stated with the estimate: 3%; at least 2.0-fold (0.30 log units) between middle value and limit.
By their numbers in this assay, from the lowest: compounds 2, 1 and 3 (each within the scatter of the next, the first and the last beyond it). At a limit, above all of these: compound 4.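

In this assay compound 4 gives a limit and not a number: the limit of > 10 ug/mL in this assay, at which 1 of the 4 values shown sits. Acetamido, on a saturated chain carbon, is thus the first group shown here for which no number results. Only an at least 3.3-fold higher number from compound 2 to compound 4 (0.52 log units; beyond the scatter) is beyond the scatter, while the floors of an at least 1.2-fold higher number from compound 3 to compound 4 (0.10 log units; that floor lies within the scatter) and an at least 1.9-fold higher number from compound 1 to compound 4 (0.28 log units; that floor lies within the scatter) lie within it, so the acetamido exchange itself remains without a firm size. The compounds shown leave open what an amine or a carboxylic acid at this place would give, and whether acetamido on a shorter chain would give a number.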